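Replacing 2-methylphenyl with 4-cyanophenyl: the expected step

The source may hold more compounds than are shown below. What is called first, only, known or untested is meant among the compounds shown, and "the series" means these compounds.

Among the compounds with values here, in a functional assay (muscle tissue) with Cavia porcellus as the target (a lower number here means that less compound is needed, a higher number that more compound is needed for the effect), compound 3 (`COC(=O)C1=C(C)N=C(C)/C(=C(\O)OC)C1c1ccccc1C`) gives 6.03 nM, the second highest of the three numbers so far. Compound 2 (`COC(=O)C1=C(C)N=C(C)/C(=C(\O)OC)C1c1c(Cl)cccc1Cl`) gives 1.91 nM, and the change between these two is modest: a 3.2-fold higher number from compound 2 to compound 3 (0.50 log units; beyond the scatter). Compound 1 (`COC(=O)C1=C(C)N=C(C)/C(=C(\O)OC)C1c1ccc(Cl)cc1`) gives 8130 nM, far higher than either.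

The next compound is compound 4 (`COC(=O)C1=C(C)N=C(C)/C(=C(\O)OC)C1c1ccc(C#N)cc1`), with 4-cyanophenyl in place of 2-methylphenyl on a saturated ring carbon. Within the data shown here, no compound with a nitrile has been measured yet. Among the measured compounds shown here, the closest reference is compound 1, the only measured compound with 4-chlorophenyl, while compound 2 and compound 3 carry 2,6-dichlorophenyl and 2-methylphenyl. Two large steps lead away from compound 1: a 4300-fold lower number from compound 1 to compound 2 (3.63 log units; beyond the scatter) and a 1300-fold lower number from compound 1 to compound 3 (3.13 log units; beyond the scatter). The second is nearly the reverse of the change now in question, differing only in nitrile against chlorine, so a large rise in this assay is expected. This rests on compound 1 alone, which leaves the size uncertain. The step expected is a 500-fold higher number from compound 3 to compound 4 (2.70 log units; beyond the scatter). For compound 4 the estimated value is 3000 nM, with an expected range from 400 nM to 20000 nM.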

Compound 4, half-maximal effective concentration: 3470 nM
Compound 4: the middle estimate sits 1.2-fold (0.06 log units) below what was measured, and the stated range covers the measured number.
By their numbers in this assay, from the lowest: compound 2; then compound 3; then compound 4; then compound 1.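

In this assay, the swap of chloro for nitrile on the 4-substituted phenyl changes little: a 2.3-fold lower number from compound 1 to compound 4 (0.37 log units; beyond the scatter) is a modest step, though beyond the scatter. The steps to the two compounds with a 2-substituted phenyl are far larger, a 580-fold higher number from compound 3 to compound 4 (2.76 log units; beyond the scatter) on one side and a 1800-fold higher number from compound 2 to compound 4 (3.26 log units; beyond the scatter) on the other, so the four compounds fall into two clear groups: 4-chlorophenyl and 4-cyanophenyl with high numbers, 2-methylphenyl and 2,6-dichlorophenyl with low numbers, and none of the four goes against this split. No supporting data are available to explain the split.

With only these four compounds, the place of the group on the phenyl ring cannot be separated from the identity of the group, since methyl appears only with a 2-substituted phenyl and nitrile only with a 4-substituted one. Matched pairs such as 4-methylphenyl against 2-methylphenyl, or 2-cyanophenyl against 4-cyanophenyl, together with unsubstituted phenyl as a reference, would show which of the two tracks the number in this assay and whether the second chlorine of 2,6-dichlorophenyl matters.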